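Aryl sulfone variation on the shared core

A few compounds are considered here, and "the series" means these few. Any claim that something is new, unique, unknown or untested is made for them only; others in the source may bear on it.

Compound 3 `Cc1ccc2ncc(S(=O)(=O)c3ccc(C)c(F)c3)c(N3CCC(C)CC3)c2c1` gives 91% in an assay on isolated protein for displacement of a labelled ligand from metabotropic glutamate receptor 5 (Homo sapiens), with a stated time of 60 min, tested at 1 uM (a lower number here means less inhibition, a higher number more inhibition at the concentration tested (going by the name of the read-out)), the second highest of three numbers. Compound 2 `Cc1ccc2ncc(S(=O)(=O)c3ccc(F)c(Cl)c3)c(N3CCC(C)CC3)c2c1` gives 93% and compound 1 `Cc1ccc2ncc(S(=O)(=O)c3cc(Cl)cc(Cl)c3)c(N3CCC(C)CC3)c2c1` gives 75%; the step of a number 2 percentage points lower from compound 2 to compound 3 (within the scatter) lies within the scatter, whereas a number 16 percentage points higher from compound 1 to compound 3 (beyond the scatter) and a number 18 percentage points higher from compound 1 to compound 2 (beyond the scatter) are modest moves beyond it. Compound 4 `COc1cccc(S(=O)(=O)c2cnc3ccc(C)cc3c2N2CCC(C)CC2)c1` carries the change (3-methoxyphenyl in place of 3-fluoro-4-methylphenyl on a sulfonyl sulfur). Among the measured compounds shown here, two earlier changes of the group on the sulfonyl sulfur moved this assay modestly, one did not; the 3-methoxyphenyl group has no precedent here. A modest downward step a number 11 percentage points lower from compound 3 to compound 4 (beyond the scatter) is therefore expected, not exceeding the scatter by much. Compound 4 is estimated at 80%, within 60% to 95%.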

Compound 4, a percentage reported as inhibition, at one concentration (the size of the read-out at that concentration, not a potency): 96%
Estimate against measurement, compound 4: 16 percentage points below, and the stated range ends below it.
By their numbers in this assay, from the lowest: compound 1; then compounds 3, 2 and 4 (each within the scatter of the next).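

On the sulfonyl sulfur, the 3-methoxyphenyl group replaces a halogen-bearing ring with one carrying a hydrogen-bond acceptor, and this assay does not separate it from the two best earlier groups (a number 5 percentage points higher from compound 3 to compound 4 (within the scatter)) and (a number 3 percentage points higher from compound 2 to compound 4 (within the scatter)). Only the 3,5-dichlorophenyl group of compound 1 stands apart (a number 21 percentage points higher from compound 1 to compound 4 (beyond the scatter)), so a halogen on this ring is not needed for a high number. Nothing available explains why the number stays level with this change.

A single concentration gives only the size of the effect at that concentration, and at it compound 2, compound 3 and compound 4 are not separated. As far as these compounds go, whether an amine, a carboxylic acid or a longer ethoxy chain on this ring would keep the number remains open.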